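A few compounds are considered here, and "the series" means these few. Any claim that something is new, unique, unknown or untested is made for them only; others in the source may bear on it.

Compound 3 `CCn1c(C(=O)Nc2ccc(OC(F)(F)F)cc2)ccc1C(CC)(CC)c1ccc(OCCC(O)(CC)CC)c(C)c1` is the compound of this small set that gives no number: in an assay on cells for agonist activity at vitamin D3 receptor (Homo sapiens), with a stated time of 96 h (a lower number here means that less compound is needed, a higher number that more compound is needed for the effect), compound 3 reaches only the assay limit, > 10000 nM, so its position rests on the limit of > 10000 nM in this assay, at which 1 of the 3 values shown sits, rather than on a measured value. Against it stand compound 1 `CCn1c(C(=O)NCC#N)ccc1C(CC)(CC)c1ccc(OCCC(O)(CC)CC)c(C)c1`, which in this assay gives 1080 nM, and compound 2 `C#CCCOC(=O)c1ccc(C(CC)(CC)c2ccc(OCCC(O)(CC)CC)c(C)c2)n1CC`, which gives 6030 nM. The measured steps run toward the limit: an at least 9.2-fold higher number from compound 1 to compound 3 (0.96 log units; beyond the scatter), and an at least 1.6-fold higher number from compound 2 to compound 3 (0.21 log units; that floor lies within the scatter), while a 5.6-fold higher number from compound 1 to compound 2 (0.75 log units; beyond the scatter).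

Compound 4 `CCC(C)C(NC(=O)c1ccc(C(CC)(CC)c2ccc(OCCC(O)(CC)CC)c(C)c2)n1CC)C(=O)O` changes the group on the amide nitrogen of compound 3: 1-carboxy-2-methylbutyl in place of 4-(trifluoromethoxy)phenyl on an amide-type nitrogen. The two measured steps that replace this same group show that the cyanomethyl amide of compound 1 sits furthest from the limit and the aryl amide of compound 3 at it; a 1-carboxy-2-methylbutyl amide has no direct precedent among these three, but it is smaller and carries a donor and an acceptor where the aryl group of compound 3 carried none. A step back toward the range of compound 1 is therefore expected, though with wide uncertainty, and an at least 4.0-fold lower number from compound 3 to compound 4 (0.60 log units; beyond the scatter) is the estimated size. Compound 4 is expected to give about 2500 nM in this assay, between 500 nM and 10000 nM.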

Compound 4, half-maximal effective concentration: 860 nM
Beside the measured number, compound 4's estimate is 2.9-fold (0.46 log units) above it; the measured number falls inside the stated range.
By their numbers in this assay, from the lowest: compounds 4 and 1 (each within the scatter of the next); then compound 2. At a limit, above all of these: compound 3.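

The amide nitrogen accepts the 1-carboxy-2-methylbutyl group, which has no ring, and the number stays with that of the cyanomethyl amide: the step is a 1.3-fold lower number from compound 1 to compound 4 (0.10 log units; within the scatter), so in this assay these two amides cannot be told apart. Compound 4 also stands clear of the (but-3-yn-1-yl)oxy ester, with a 7.0-fold lower number from compound 2 to compound 4 (0.85 log units; beyond the scatter), so a second amide now shows the gap first seen with compound 1, while compound 3 remains the amide that goes against any general advantage of amides over this ester. Replacing the 4-(trifluoromethoxy)phenyl group gives an at least 11-fold lower number from compound 3 to compound 4 (1.06 log units; beyond the scatter), and that size is only a floor, since compound 3 stands at a limit: the limit of > 10000 nM in this assay, at which 1 of the 4 values shown sits.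

The compounds shown do not separate the carboxylic acid of compound 4 from its branched carbon chain, which a methyl ester or a plain 2-methylbutyl amide on the same nitrogen would do. Going by these compounds, it also remains open whether an unsubstituted phenyl amide stands with compound 3 at the limit, or whether the trifluoromethoxy group is what places it there.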